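The source may report more compounds than this note shows. Statements on the series, on what has been measured and on what is new or still open speak of the compounds shown alone.

In an ADME assay on cells (Hepatocyte, Homo sapiens) for metabolic stability, read by LC-MS, with a stated time of 3 h, tested at 1 uM (on this read-out higher numbers stand for fast clearance and lower numbers for slow clearance), compound 3 `CS(=O)(=O)NC(=O)c1cc(C2CC2)c(OCC2CCN(C(c3ccccc3)c3ccccc3)CC2)cc1F` gives < 6.2 mL/min/kg, which is a limit and not a number. Compound 1 `CC(C)(c1cc(Cl)cc(Cl)c1)N1CCC(COc2cc(F)c(C(=O)NS(C)(=O)=O)cc2C2CC2)CC1` gives < 6.2 mL/min/kg, also a limit. These two readings rest on (the limit of < 6.2 mL/min/kg in this assay, at which 2 of the 3 values shown sit). Compound 2 `CS(=O)(=O)NC(=O)c1cc(C2CC2)c(OCC2CCN(Cc3ccc(Cl)cc3)CC2)cc1F`, by contrast, gives a measured 15 mL/min/kg.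

Compound 4 `CS(=O)(=O)NC(=O)c1cc(C2CC2)c(OCC2CCN(Cc3ccccc3)CC2)cc1F` differs from compound 3 by hydrogen in place of phenyl on a saturated chain carbon bound to an amine nitrogen in a ring and an aromatic carbon.

Among the measured compounds shown here, the one measured step that bears on this change is an at least 2.4-fold higher number from compound 1 to compound 2 (0.38 log units; beyond the scatter). There, too, groups on the chain carbon bound to the amine nitrogen give way to hydrogen, and the number rises beyond the scatter. For the measured compounds named here, only this single step supports the comparison, so the expectation is a rough one. The expected change is an at least 2.4-fold higher number from compound 3 to compound 4 (0.38 log units; beyond the scatter), an upward step beyond the scatter, towards faster clearance. Compound 4 is estimated at 15 mL/min/kg, with an expected range of 7 mL/min/kg to 32 mL/min/kg.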

Compound 4, clearance: 15 mL/min/kg
Compound 4: middle estimate and measured number agree at the digits printed, and the stated range covers the measured number.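

In this assay the chain carbon bound to the amine nitrogen in a ring now has a direct test, as hydrogen in place of phenyl there gives an at least 2.4-fold higher number from compound 3 to compound 4 (0.38 log units; beyond the scatter) on a single change. Hydrogen in place of chloro on an aromatic carbon gives no change at the digits printed from compound 2 to compound 4 (within the scatter) and so leaves the reading in place, which means the chloro of compound 2 does not account for its faster clearance. Benzyl in place of 1-(3,5-dichlorophenyl)-1-methylethyl gives an at least 2.4-fold higher number from compound 1 to compound 4 (0.38 log units; beyond the scatter) and, like the phenyl step, starts from a limit, so the full size of both steps remains unknown: (the limit of < 6.2 mL/min/kg in this assay, at which 2 of the 4 values shown sit).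

Still open, on these data alone, is how a single methyl on that chain carbon would read, and whether it would fall between these readings. Also open, as far as these compounds go, is what a methoxy or a nitrile on the benzyl ring would do to clearance.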